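Swapping a Hydroxymethylpiperidine for a Hydroxycyclopentylamine

The source may hold more compounds than are shown below. What is called first, only, known or untested is meant among the compounds shown, and "the series" means these compounds.

Measured so far:
Compound 1, `COc1cc[nH]c1/C=C1\C(=O)Nc2ccc([N+](=O)[O-])c(N[C@H]3CC[C@H](O)CC3)c21`: 8550 nM
Compound 2, `COc1cc[nH]c1/C=C1\C(=O)Nc2ccc([N+](=O)[O-])c(N3CCCC(CO)C3)c21`: 441 nM

Both compounds share one core and were tested in a functional assay on MDA-MB-435 cells (Homo sapiens) for antiproliferative activity, read by MTT assay, with a stated time of 5 days; a higher number here means a weaker inhibitor, a lower number a stronger inhibitor. Among the measured compounds shown here, compound 2 has the lowest number of the two, and the only measured step is a 19-fold lower number from compound 1 to compound 2 (1.29 log units; beyond the scatter). That step replaced a secondary amine bearing a hydroxylated carbocycle with a tertiary ring amine carrying a hydroxymethyl group.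

Compound 3, `COc1cc[nH]c1/C=C1\C(=O)Nc2ccc([N+](=O)[O-])c(N[C@H]3CC[C@H](O)C3)c21`, differs from compound 2 in one place: (3-hydroxycyclopentyl)amino in place of 3-(hydroxymethyl)piperidin-1-yl on an aromatic carbon. The change largely undoes the earlier one, bringing back a secondary amino group attached to a hydroxylated carbocycle, much like compound 1, though the ring is now five-membered and the hydroxyl sits at a different position. Because the step of a 19-fold lower number from compound 1 to compound 2 (1.29 log units; beyond the scatter) was large, and the present change runs in the opposite structural direction, a large rise in the number in this assay is expected, though the ring difference leaves room for a partial rather than complete reversal.

Compound 3 is therefore expected to give about 4000 nM in this assay, within a range from 1000 nM to 16000 nM. This expected change corresponds to a 9.1-fold higher number from compound 2 to compound 3 (0.96 log units; beyond the scatter).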

Compound 3, half-maximal inhibitory concentration: 1000 nM
The estimate for compound 3 lay 4.0-fold (0.60 log units) above the measured number; the range from low to high includes it.
By their numbers in this assay, from the lowest: compound 2; then compound 3; then compound 1.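

In this assay, keeping the secondary amino link and changing only the hydroxylated carbocycle gives an 8.6-fold lower number from compound 1 to compound 3 (0.93 log units; beyond the scatter), so having a secondary amine at this position does not by itself bring the weak number of compound 1. In the other direction, the change gives a 2.3-fold higher number from compound 2 to compound 3 (0.36 log units; beyond the scatter), a modest step that is still beyond the usual scatter, and compound 2 keeps the lowest number of the three. The large gap between compound 1 and compound 2 therefore cannot be read as a simple effect of the kind of nitrogen, since the carbocycle on that nitrogen also shifts the number substantially at this aromatic carbon, ortho to a nitro group.

Ring size and hydroxyl position change together between compound 1 and compound 3, so their separate contributions remain unknown, as does the value of the hydroxyl itself, which a plain cyclopentylamino or a morpholin-4-yl group at this position could test. Nothing available here accounts for why these numbers differ.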